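Swapping an allyloxyphenyl for a tolyl group

This account rests on a few compounds, and the source may have more. Where it says the series, first, only, none or still open, it means among the compounds named here.

Compound 2 `C=CCOc1cccc(-c2nc3c(NC4CCCC4)cccn3c2-c2ccnc(NC3CCCC3)n2)c1` and compound 1 `Oc1cccc(-c2nc3c(NC4CCCC4)cccn3c2-c2ccnc(NC3CCCC3)n2)c1` share one core and differ only by an allyl in place of hydrogen on an oxygen on an aromatic ring. In an ADME assay on Vero cells (Chlorocebus sabaeus) for cytotoxicity (on this read-out higher numbers stand for lower toxicity in this test and lower numbers for higher toxicity in this test), compound 1 gives > 40000 nM, which is a limit of the test and not a number. In this assay compound 2 likewise gives only a limit, > 40000 nM. The step that the two limits leave unreadable from compound 1 to compound 2 therefore cannot be read, and compound 2 stands at the limit alongside compound 1, as shown by the limit of > 40000 nM in this assay, at which 2 of the 2 values shown sit. Compound 3 `Cc1ccc(-c2nc3c(NC4CCCC4)cccn3c2-c2ccnc(NC3CCCC3)n2)cc1` changes a different part: 4-methylphenyl in place of 3-(allyloxy)phenyl on an aromatic carbon. Among the measured compounds shown here, no measured step covers an exchange of this kind, and the only measured step, a step that the two limits leave unreadable from compound 1 to compound 2, is unreadable. Both values seen so far sit at the limit (the limit of > 40000 nM in this assay, at which 2 of the 2 values shown sit), so compound 3 is expected to show no step beyond the scatter, a step that the limit leaves unreadable from compound 2 to compound 3. The estimate for compound 3 in this assay is 50000 nM, with a range from 20000 nM to 150000 nM.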

Compound 3, half-maximal cytotoxic concentration: > 40000 nM
Compound 3: a limit, no number (the forecaster's own chance of this, stated with the estimate: 75%); the middle value is on the limit's open side.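

In this assay compound 3 gives > 40000 nM, again a limit of the test and not a number, so its steps from compound 1 and compound 2 cannot be read. Whether these three compounds truly differ in this assay stays open, with all of them at one limit: the limit of > 40000 nM in this assay, at which 3 of the 3 values shown sit.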